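The source may report more compounds than this note shows. Statements on the series, on what has been measured and on what is new or still open speak of the compounds shown alone.

Working notes on a small set of glycoside-linked nitroaryl oxadiazoles and a related isoxazoline, all tested in a functional assay on WiDr cells (Homo sapiens) for antiproliferative activity, read by sulforhodamine B assay, with a stated time of 48 h; on this read-out higher numbers stand for weaker inhibition of growth and lower numbers for stronger inhibition of growth.

Compound 1 `COc1cc(C2=NOC(CO[C@@H]3O[C@H](CSc4ncn[nH]4)[C@H]4OC5(CCCC5)O[C@@H]34)C2)cc(OC)c1OC` gives 53000 nM in this assay. Compound 2 `CC1(C)O[C@H]2[C@H](OCc3noc(-c4ccc([N+](=O)[O-])cc4)n3)O[C@H](CO)[C@H]2O1` yields only a limit of this assay, > 100000 nM, so no number is available for it; the limit is the one noted in the limit of > 100000 nM in this assay, at which 1 of the 3 values shown sits. Compound 3 `CC(=O)OC[C@H]1O[C@@H](OCc2noc(-c3ccc([N+](=O)[O-])cc3)n2)[C@@H]2OC3(CCCC3)O[C@@H]21` gives 36000 nM, the lowest of the two numbers in hand, although compound 1 lies within the scatter of it, so no order between the two is claimed. All numbers here sit at the weak end of the read-out.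

Compound 4 `Cc1ccc(S(=O)(=O)OC[C@H]2O[C@@H](OCc3noc(-c4ccc([N+](=O)[O-])cc4)n3)[C@@H]3OC4(CCCC4)O[C@@H]32)cc1` has not been measured. Against compound 3 it differs by (4-methylphenyl)sulfonyl in place of acetyl on an oxygen on a saturated carbon. For the measured compounds named here, no measured step of this kind is available in the set. In this assay the change from compound 3 to compound 4 is expected to yield a step of a 1.2-fold lower number from compound 3 to compound 4 (0.08 log units; within the scatter), not clearly beyond the scatter in either direction. Compound 4 is therefore estimated at 30000 nM, with a range from 8000 nM to 100000 nM.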

Compound 4, concentration for 50% growth inhibition: > 100000 nM
Compound 4 was reported as a limit (the forecaster's own chance of this, stated with the estimate: 20%); middle value at least 3.3-fold (0.52 log units) from the limit.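

At the oxygen on a saturated carbon, (4-methylphenyl)sulfonyl in place of acetyl gives an at least 2.7-fold higher number from compound 3 to compound 4 (0.44 log units; beyond the scatter) in this assay, so what this position carries does matter for the read-out. For the compounds shown here, this is the first step that can be read between two compounds differing in one place, and the weak inhibition of growth seen with acetyl does not survive the change. Compound 4 is a limit of the assay and not a number, so the full size of the step stays unknown, and limits now make up a large part of the set: the limit of > 100000 nM in this assay, at which 2 of the 4 values shown sit.

As far as these compounds go, it remains open whether the sulfonyl or the aromatic ring goes with the change, which a methanesulfonyl group and a benzoyl group at this position would separate. Also open, from the compounds shown here alone, is whether an amine here would move the read-out in the other direction.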